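Amine substituent on the shared core: compound 3

The compounds below may be only part of what the source reports. "The series", "measured", "known", "first", "only" and "open" are said of these compounds alone.

Compound 2 `Fc1ccccc1Cn1nnc2c(NC3CC3)nc(-c3ccccc3)nc21` gives 15 nM in an assay on Cerebral cortex for displacement of a labelled ligand from adenosine receptor A1 (Bos taurus); a lower number here means a stronger inhibitor, a higher number a weaker inhibitor. Going by the values given here, of the two numbers measured so far it is the higher one; the nearest is compound 1 `CCCNc1nc(-c2ccccc2)nc2c1nnn2Cc1ccccc1F`, which in this assay gives 3.2 nM. Among the compounds with values here, the single measured step runs between these two: a 4.7-fold higher number from compound 1 to compound 2 (0.67 log units; beyond the scatter), a change of propyl to cyclopropyl on the nitrogen on the aromatic ring.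

Compound 3 `Fc1ccccc1Cn1nnc2c(NC3CCCCC3)nc(-c3ccccc3)nc21` is not yet measured. It differs from compound 2 in one place: cyclohexyl in place of cyclopropyl on a nitrogen on an aromatic ring. Within the data shown here, the only step that bears on this exchange is the one from compound 1 to compound 2, which was modest and beyond the scatter; it concerns the same nitrogen but a different pair of groups, and no measured step shows how a six-membered non-aromatic ring of carbon only fares there. The direction of the exchange is therefore open.

Compound 3 is expected to stay close to compound 2 in this assay, with a drift toward a lower number of a 1.5-fold lower number from compound 2 to compound 3 (0.18 log units; within the scatter). For compound 3 the estimated value is 10 nM, with an expected range from 3 nM to 40 nM.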

Compound 3, inhibition constant: 1.15 nM
Compound 3: the middle estimate sits 8.7-fold (0.94 log units) above what was measured; the measured number lies below the stated range.
By their numbers in this assay, from the lowest: compound 3; then compound 1; then compound 2.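

In this assay, going by these compounds alone, this nitrogen on an aromatic ring proves far more sensitive to the choice of carbon-only ring than the earlier pair suggested: the exchange of cyclopropyl for cyclohexyl gives a 13-fold lower number from compound 2 to compound 3 (1.12 log units; beyond the scatter) and is the only step graded large. A non-aromatic ring on this nitrogen does not set the direction of change relative to propyl, since cyclopropyl gives a 4.7-fold higher number from compound 1 to compound 2 (0.67 log units; beyond the scatter) while cyclohexyl gives a 2.8-fold lower number from compound 1 to compound 3 (0.44 log units; beyond the scatter) in the opposite direction. Compound 3 is therefore the strongest of the three, with its steps to both others beyond the scatter, and nothing available here accounts for the size or direction of these steps.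

Within the data shown here, with only three groups at this nitrogen, the shape of the dependence on ring size remains open: cyclopentyl and cycloheptyl would show whether cyclohexyl is a peak or part of a continuing trend. From the compounds shown here alone, it is also open whether the low number survives a hydroxyl or an amine on the cyclohexyl ring, or a phenyl in its place, and whether a longer straight chain than propyl can match cyclohexyl.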